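Allyl Substitution on a Dichlorophenyl Diketopiperazine Analogue

This account rests on a few compounds, and the source may have more. Where it says the series, first, only, none or still open, it means among the compounds named here.

Compound 1 `COc1ccccc1/C=c1/[nH]c(=O)/c(=C\c2cccc(Cl)c2Cl)[nH]c1=O`: "not determined" (no result reported)
Compound 2 `C=CCn1c(=O)/c(=C\c2ccccc2Cl)[nH]c(=O)/c1=C\c1ccccc1OC`: 4400 nM

In a functional assay on MOLT-4 cells (Homo sapiens) for cytotoxicity, read by CCK-8 assay, with a stated time of 72 h (on this read-out higher numbers stand for weaker inhibition and lower numbers for stronger inhibition), compound 1 is recorded as "not determined" (no result reported), so nothing is known of its own potency; only compound 2 carries a value, 4400 nM. Compound 3 `C=CCn1c(=O)/c(=C\c2cccc(Cl)c2Cl)[nH]c(=O)/c1=C\c1ccccc1OC` arises from compound 1 by the change (allyl in place of hydrogen on an aromatic nitrogen), allyl in place of hydrogen on an aromatic nitrogen. Among the compounds with values here, with no measured step for this change, the expected size in this assay cannot be read from a pair, and compound 3 is expected to fall near the single value shown. Compound 3 is estimated at 4000 nM, within 1000 nM to 16000 nM.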

Compound 3, half-maximal inhibitory concentration: 1200 nM
Compound 3: the middle estimate sits 3.3-fold (0.52 log units) above what was measured, and the stated range covers the measured number.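

With allyl on the aromatic nitrogen in both compounds, a chloro in place of hydrogen on an aromatic carbon gives a 3.7-fold lower number from compound 2 to compound 3 (0.56 log units; beyond the scatter) in this assay, so this added chloro changes the read-out beyond the scatter. From the compounds shown here alone, the step for allyl in place of hydrogen cannot be read, and the contribution of the allyl group itself stays unknown. Nothing at hand gives a reason for the chloro step. Open, going by these compounds, is how a longer chain or a carboxylic acid on that nitrogen would compare with allyl.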